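A few compounds are considered here, and "the series" means these few. Any claim that something is new, unique, unknown or untested is made for them only; others in the source may bear on it.

Measured so far:
compound 1 `C=CCc1cc(C(C)=O)c(O)cc1OCCCCC#N`: 57%
compound 2 `C=CCc1cc(C(C)=O)c(O)cc1OCCCCC`: 23%

Going by the values given here, in an assay on isolated protein for binding affinity to leukotriene B4 receptor 1 (Homo sapiens), tested at 1 uM (on this read-out higher numbers stand for more inhibition at the one concentration tested (going by the name of the read-out) and lower numbers for less inhibition), compound 1 gives 57%, the higher of the two numbers; the only measured step, a number 34 percentage points lower from compound 1 to compound 2 (beyond the scatter), concerns exchanging the cyano group on the chain for a methyl. Compound 3 `C=CCc1cc(C(=O)CC)c(O)cc1OCCCCC#N` differs from compound 1 at another place: methyl in place of hydrogen on a saturated chain carbon bound to a carbonyl carbon, so acetyl becomes propanoyl. Among the compounds with values here, no measured step touches that carbon, and the known step therefore gives no guide here. For compound 3 the expected step is a number 2 percentage points lower from compound 1 to compound 3 (within the scatter), within the scatter. Compound 3 is estimated at 55%, between 35% and 72%.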

Compound 3, a percentage reported as inhibition, at one concentration (the size of the read-out at that concentration, not a potency): 36%
For compound 3 the middle estimate is 19 percentage points above the measured one; the measured number falls inside the stated range.
By their numbers in this assay, from the lowest: compound 2; then compound 3; then compound 1.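

Going from acetyl to propanoyl gives a number 21 percentage points lower from compound 1 to compound 3 (beyond the scatter) in this assay and so shows that this carbon also matters to the read-out, not only the cyano group on the other chain. A single added methyl on the saturated chain carbon bound to the carbonyl carbon is enough to produce a step beyond the scatter. No measurement on hand explains this drop.

On these data alone, whether a longer chain such as butanoyl, or an amine on this carbon, would lower the number further or restore it stays open. So does whether the same methyl has a similar effect on compound 2, which lacks the cyano group.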